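Exchanging bromo for an amide on a shared core

The source may hold more compounds than are shown below. What is called first, only, known or untested is meant among the compounds shown, and "the series" means these compounds.

Compound 1: `COc1ccccc1-c1csc(NC(=O)c2ccc([N+](=O)[O-])o2)n1` — 42000 nM
Compound 2: `O=C(Nc1nc(-c2cccc(Br)c2)cs1)c1ccc([N+](=O)[O-])o1` — 71000 nM

In an ADME assay on Vero cells (Chlorocebus sabaeus) for cytotoxicity, read by MTT assay, with a stated time of 72 h (on this read-out lower numbers stand for stronger inhibition and higher numbers for weaker inhibition), compound 1 gives 42000 nM, and compound 2 gives 71000 nM. Among the measured compounds shown here, the one step measured between them, a 1.7-fold higher number from compound 1 to compound 2 (0.23 log units; within the scatter), is the only guide available here. On the two numbers shown, compound 2 and compound 1 lie within the scatter of each other, so neither stands apart from the other.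

Compound 3, `O=C(Nc1nc(-c2cccc(NC(=O)C3CC3)c2)cs1)c1ccc([N+](=O)[O-])o1`, is not yet measured. It differs from compound 2 in one place: (cyclopropylcarbonyl)amino in place of bromo on an aromatic carbon. For the measured compounds named here, the only measured step that bears on this change is the one from compound 1 to compound 2, which also swapped the group on the same six-membered ring of carbon and moved the number by a 1.7-fold higher number from compound 1 to compound 2 (0.23 log units; within the scatter), that is, not beyond the scatter. Nothing measured speaks for or against a larger effect of the incoming (cyclopropylcarbonyl)amino group. The expectation for compound 3 in this assay is therefore a step of about a 1.2-fold lower number from compound 2 to compound 3 (0.07 log units; within the scatter), essentially no change beyond the scatter, with a wide range to allow for the untested group. Compound 3 is estimated at 60000 nM, between 25000 nM and 150000 nM.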

Compound 3, half-maximal inhibitory concentration: 35700 nM
The estimate for compound 3 lay 1.7-fold (0.23 log units) above the measured number; low and high end bracket the measured number.
By their numbers in this assay, from the lowest: compounds 3, 1 and 2 (each within the scatter of the next).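

In this assay, putting (cyclopropylcarbonyl)amino in place of bromo gives a 2.0-fold lower number from compound 2 to compound 3 (0.30 log units; within the scatter) and stays within the scatter, so this exchange does not produce a clear difference in the measured number. The earlier step compared two different aryl groups, whereas this one tests a much larger substituent on an aromatic carbon, meta to a large group. The incoming group brings a three-membered ring of carbon, a hydrogen-bond donor and a hydrogen-bond acceptor, yet compound 3 cannot be told apart from compound 2 in this read-out, and no measured evidence is available to explain this result.

These compounds leave open whether a free amine or a carboxylic acid at this same place would also stay within the scatter, since a charged or unacylated group could behave differently from the neutral amide shown here. On these data alone, it also remains open whether replacing the cyclopropyl part of the amide with a longer carbon chain would move the number beyond the scatter, or leave it just as close to compound 2.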